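Chain-end change from compound 3 to compound 4

The compounds below may be only part of what the source reports. "The series", "measured", "known", "first", "only" and "open" are said of these compounds alone.

In an ADME assay for permeability, using PAMPA, with a stated time of 4 h, at pH 7.4 (a lower number here means that the compound crosses the layer more slowly, a higher number that the compound crosses the layer faster), compound 1 `NC(=O)NCCCCN(C[C@H]1Cc2ncccc2CN1)[C@H]1CCCc2cccnc21` gives 2 nm/s and compound 2 `NC(=O)NC/C=C\CN(C[C@H]1Cc2ncccc2CN1)[C@H]1CCCc2cccnc21` gives 2 nm/s. The no change at the digits printed from compound 1 to compound 2 (within the scatter) therefore shows no separation between these two. Compound 3 `CN(CCCCN(C[C@H]1Cc2ncccc2CN1)[C@H]1CCCc2cccnc21)C1CCC(F)(F)CC1` gives 310 nm/s, the highest of the three numbers and clear of the other two by far more than the scatter.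

Compound 4 `c1cnc2c(c1)CN[C@@H](CN(CCCCNC1COC1)[C@H]1CCCc3cccnc31)C2` has not been measured. Its difference from compound 3 is a group of 5 heavy atoms (3 carbon, 1 nitrogen, 1 oxygen; one four-membered non-aromatic ring with 1 hetero atom) in place of a group of 10 heavy atoms (7 carbon, 1 nitrogen, 2 fluorine; one six-membered non-aromatic ring of carbon only), on a saturated chain carbon, four bonds along the chain from an amine nitrogen. The entering group is (oxetan-3-yl)amino, and the leaving group has no common name.

The measured change at this same place on the chain is a 160-fold higher number from compound 1 to compound 3 (2.19 log units; beyond the scatter), a large step. The group in compound 1 is closer in heavy-atom count to the entering group than to the group in compound 3, so part of that step is expected to be reversed. The change in compound 2 lies elsewhere and says little about this place. Going by the values given here, no measured compound carries the entering group, so the size remains uncertain. A substantial drop in this assay is expected, though less than the full measured step. The expected change is a 21-fold lower number from compound 3 to compound 4 (1.32 log units; beyond the scatter). The estimate for compound 4 is 15 nm/s, with an expected range of 3 nm/s to 80 nm/s.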

Compound 4, apparent permeability: 300 nm/s
For compound 4 the middle estimate is 20-fold (1.30 log units) below the measured one; measured number outside the range, above it.
By their numbers in this assay, from the lowest: compounds 1 and 2 (each within the scatter of the next); then compounds 4 and 3 (each within the scatter of the next).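

At the saturated chain carbon four bonds along the chain from an amine nitrogen, this assay gives a 1.0-fold lower number from compound 3 to compound 4 (0.01 log units; within the scatter), so a large carbocyclic end group is not needed for the high number: (oxetan-3-yl)amino, with fewer heavy atoms, reads the same as the leaving group. The step of a 150-fold higher number from compound 1 to compound 4 (2.18 log units; beyond the scatter) sets the low number of compound 1 against compound 4, and the step of a 150-fold higher number from compound 2 to compound 4 (2.18 log units; beyond the scatter) does the same for compound 2. The first of these is a single exchange of oxetan-3-yl for carbamoyl on an amine nitrogen, so within these four compounds heavy-atom count at the chain end does not follow the number, while the two carbamoyl compounds stand alone at the low end. No measurement offered here explains the gap between the carbamoyl and oxetan-3-yl ends.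

As far as these compounds go, it stays open whether an acetyl group or a plain primary amine at the chain end would read with the carbamoyl compounds or with compounds 3 and 4. A carboxylic acid at that place, or a longer chain carrying (oxetan-3-yl)amino, would test how far the high number extends.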